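Working notes: the step from compound 2 to compound 4

The source may hold more compounds than are shown below. What is called first, only, known or untested is meant among the compounds shown, and "the series" means these compounds.

Measured so far in a functional assay (aorta) with Rattus norvegicus as the target; on this read-out lower numbers stand for an effect already at smaller amounts and higher numbers for an effect only at larger amounts of compound:
compound 1 `COc1ccc(-c2nc(/N=C(\N)N(C)C)sc2-c2ccc(OC)cc2)cc1` gives 4.8 uM;
compound 2 `COc1ccc(-c2nc(CNC(C)=O)sc2-c2ccc(OC)cc2)cc1` gives 8.1 uM;
compound 3 `COc1ccc(-c2nc(CNC(=O)C3=NNC(=O)CC3)sc2-c2ccc(OC)cc2)cc1` gives 7.3 uM.

Compound 2 holds the highest of the three numbers, but this separates it from nothing: a 1.7-fold higher number from compound 1 to compound 2 (0.23 log units; within the scatter) and a 1.1-fold lower number from compound 2 to compound 3 (0.05 log units; within the scatter), so all three sit together within the usual scatter.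

The unmeasured compound 4 `COc1ccc(-c2nc(C(=O)N=C(N)N)sc2-c2ccc(OC)cc2)cc1` differs from compound 2 at the group on the aromatic carbon of the five-membered aromatic ring, the one next to the ring nitrogen and the ring sulfur: a group of 6 heavy atoms (2 carbon, 3 nitrogen, 1 oxygen; no ring) in place of a group of 5 heavy atoms (3 carbon, 1 nitrogen, 1 oxygen; no ring), on an aromatic carbon. The entering group, with two hydrogen-bond donors and two double bonds outside aromatic rings, resembles in size the group of 6 heavy atoms carried at the same place by compound 1.

Both measured steps bear on this change, since each also swaps the group at this position, and both stayed within the scatter. Nothing seen so far in this assay moves the read-out beyond the scatter when this group is exchanged, so no step beyond the scatter is expected here either: a 1.4-fold lower number from compound 2 to compound 4 (0.13 log units; within the scatter) is what these notes expect. Compound 4 is therefore estimated at 6 uM, with a range from 2.5 uM to 15 uM.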

Compound 4, concentration for half-maximal effect: > 100 uM
Compound 4: only a limit was reported; the forecaster's own chance of this, stated with the estimate: 10%; middle value at least 16-fold (1.22 log units) away from the limit.
By their numbers in this assay, from the lowest: compounds 1, 3 and 2 (each within the scatter of the next). At a limit, above all of these: compound 4.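

In this assay, compound 4 is reported only as a limit and not as a number: the limit of > 100 uM in this assay, at which 1 of the 4 values shown sits.

Even read from that limit, the position proves sensitive to exchange, which the earlier steps did not show: the read-out gives an at least 12-fold higher number from compound 2 to compound 4 (1.09 log units; beyond the scatter), and also an at least 20-fold higher number from compound 1 to compound 4 (1.31 log units; beyond the scatter), whereas the groups of compounds 1, 2 and 3 all stayed within the scatter of one another. Size counted in heavy atoms does not decide the outcome, since compound 1 and compound 4 both carry a group of 6 heavy atoms on this aromatic carbon and still lie beyond the scatter of each other.

The compounds shown leave open which part of the entering group carries the step, the carbonyl bound to the aromatic carbon or the nitrogen-rich end behind it. A carboxylic acid or a plain primary amide on this carbon would separate these two parts, and a one-carbon chain placed between the ring and the entering group would show whether the carbonyl must sit directly on the ring for the step to appear.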